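The source may report more compounds than this note shows. Statements on the series, on what has been measured and on what is new or still open speak of the compounds shown alone.

For the measured compounds named here, in an ADME assay on microsomes from liver (Macaca fascicularis) for metabolic stability, read by LC-MS, with a stated time of 65 min, tested at 1 uM (a higher number here means that more of the compound is left, a lower number that less of the compound is left), compound 1 `Cc1ncncc1-c1nc2cc(F)c(F)cc2n1C1CC1` gives 72%, while compound 2 `N#Cc1ncncc1-c1nc2cc(F)c(F)cc2n1C1CC1` gives 85%, the higher of the two numbers so far. Compound 3 `Fc1cc2nc(-c3cncnc3C(F)(F)F)n(C3CC3)c2cc1F` now follows from compound 2, with trifluoromethyl in place of cyano on an aromatic carbon. Going by the values given here, only one measured step bears on this change, a number 13 percentage points higher from compound 1 to compound 2 (beyond the scatter), a modest one that involves the same cyano group. Among the compounds with values here, no compound measured so far carries trifluoromethyl, so that step gives only a rough idea of how far a change of this group can move the number. With compound 2 already high, a small drop or no change beyond the scatter is expected in this assay, and the estimated step is a number 4 percentage points lower from compound 2 to compound 3 (within the scatter). For compound 3, the estimated value is 81%, with an expected range from 67% to 93%.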

Compound 3, percent of the compound remaining: 99%
Beside the measured number, compound 3's estimate is 18 percentage points below it; measured number outside the range, above it.
By their numbers in this assay, from the lowest: compound 1; then compound 2; then compound 3.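

In this assay, the aromatic carbon next to the ring nitrogen still left room for a rise after cyano: trifluoromethyl in place of cyano gives a number 14 percentage points higher from compound 2 to compound 3 (beyond the scatter) in this comparison. Against methyl at the same carbon, trifluoromethyl gives a number 27 percentage points higher from compound 1 to compound 3 (beyond the scatter) and thus the largest step shown, so the three groups now stand in the order methyl, cyano, trifluoromethyl, with every step between them beyond the scatter. No independent measurement shown here explains this order.

As far as these compounds go, how an amine, a methoxy group or a carboxylic acid at this carbon would read remains open. From the compounds shown here alone, it is also open whether the same order of methyl, cyano and trifluoromethyl would hold if another part of the shared core were changed.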